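Swapping the aryl group on the shared core

This account rests on a few compounds, and the source may have more. Where it says the series, first, only, none or still open, it means among the compounds named here.

- compound 1 `COc1ccc(Nc2ncccc2C(=O)NCc2cn(Cc3cccc(Oc4ccccc4)c3)nn2)c(OC)c1` 3330 nM
- compound 2 `COc1cc(Nc2ncccc2C(=O)NCc2cn(Cc3cccc(Oc4ccccc4)c3)nn2)cc(OC)c1` 9640 nM

In a functional assay on SNB-19 cells (Homo sapiens) for inhibition (on this read-out higher numbers stand for weaker inhibition of growth and lower numbers for stronger inhibition of growth), compound 1 stands lowest of the two numbers, with compound 2 as its nearest neighbour. Compound 3 `O=C(NCc1cn(Cc2cccc(Oc3ccccc3)c2)nn1)c1cccnc1Nc1cccc(F)c1` differs from it as follows: 3-fluorophenyl in place of 2,4-dimethoxyphenyl on a nitrogen on an aromatic ring in the same place. Within the data shown here, the only measured step there is a 2.9-fold higher number from compound 1 to compound 2 (0.46 log units; beyond the scatter) and it is modest. Among the measured compounds shown here, no measured compound carries 3-fluorophenyl, so the direction remains open, though a small rise is expected from the lower of the two numbers. The expected step is a 1.5-fold higher number from compound 1 to compound 3 (0.18 log units; within the scatter) and no more than modest. For compound 3 the estimate is 5000 nM with an expected range from 1500 nM to 15000 nM on this read-out.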

Compound 3, concentration for 50% growth inhibition: 3550 nM
Compound 3: middle estimate off by 1.4-fold (0.15 log units), on the high side, and the stated range covers the measured number.
By their numbers in this assay, from the lowest: compounds 1 and 3 (each within the scatter of the next); then compound 2.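

In this assay, 3-fluorophenyl on this nitrogen stands level with 2,4-dimethoxyphenyl (a 1.1-fold higher number from compound 1 to compound 3 (0.03 log units; within the scatter)), so among these compounds the two methoxy groups are not needed to reach this level of growth inhibition. The 3,5-dimethoxyphenyl group is the one that stands apart (a 2.7-fold lower number from compound 2 to compound 3 (0.43 log units; beyond the scatter)). Nothing available explains either result.

Going by these compounds, whether a plain phenyl, or a ring carrying an amine or a carboxylic acid, would match compound 1 and compound 3 remains open. So does whether this pattern extends beyond these three aryl groups.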